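The source may report more compounds than this note shows. Statements on the series, on what has been measured and on what is new or still open speak of the compounds shown alone.

Three compounds have been measured in a functional assay on A549 cells (Homo sapiens) for cytotoxicity, read by MTT assay, with a stated time of 48 h; on this read-out higher numbers stand for weaker inhibition and lower numbers for stronger inhibition:

Compound 1, `COc1ccc2c(c1)nc(/C=C1\SC(=S)N(CC(=O)O)C1=O)n2Cc1ccc(C)cc1`, gives 5680 nM.
Compound 2, `Cc1ccc(Cn2c(/C=C3\SC(=S)NC3=O)nc3ccccc32)cc1`, gives 5310 nM.
Compound 3, `COc1ccc2c(c1)nc(/C=C1\SC(=S)N(CC(=O)O)C1=O)n2Cc1ccccc1F`, gives 18400 nM.

Compound 1 and compound 2 share much of their framework, but how the two cores differ is not broken down here; their values in this assay lie within the scatter of each other, so no order between them can be read from these numbers. Compound 3 stands apart from both, with a number beyond the scatter above each of them.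

Among the compounds with values here, the one counted change is that from compound 1 to compound 3: 2-fluorophenyl in place of 4-methylphenyl on a saturated chain carbon bound to an aromatic nitrogen. In this assay this gave a 3.2-fold higher number from compound 1 to compound 3 (0.51 log units; beyond the scatter), a modest weakening of the cytotoxic effect.

Compound 4, `O=C1NC(=S)S/C1=C\c1nc2ccccc2n1Cc1ccccc1F`, has not yet been measured in this assay. It differs from compound 2 by the same change: 2-fluorophenyl in place of 4-methylphenyl on a saturated chain carbon bound to an aromatic nitrogen, at the same place as before. Within the data shown here, because the step of a 3.2-fold higher number from compound 1 to compound 3 (0.51 log units; beyond the scatter) was the only time this change has been seen, the expectation for compound 4 rests on a single precedent applied to compound 2 and its value 5310 nM. On that basis, compound 4 is expected to show a 3.2-fold higher number from compound 2 to compound 4 (0.51 log units; beyond the scatter). The estimated value for compound 4 in this assay is therefore 17000 nM, with a likely range from 8000 nM to 36000 nM.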

Compound 4, half-maximal inhibitory concentration: > 50000 nM
Compound 4: no number, only a limit; the forecaster's own chance of this, stated with the estimate: 10%; at least 2.9-fold (0.46 log units) between middle value and limit.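

In this assay compound 4 gives no number, only a limit of the assay: > 50000 nM. Placing 2-fluorophenyl where 4-methylphenyl stood, on a saturated chain carbon bound to an aromatic nitrogen, gave an at least 9.4-fold higher number from compound 2 to compound 4 (0.97 log units; beyond the scatter), so the number rose on both cores, but the size of the step did not carry over: the same change on two cores in this assay, a 3.2-fold higher number (0.51 log units; beyond the scatter) from compound 1 to compound 3 and an at least 9.4-fold higher number (0.97 log units; beyond the scatter) from compound 2 to compound 4, at least 2.9-fold (0.46 log units) apart, beyond the scatter of two such steps. This shows that, in these two pairs, the direction of the change held while its size depended on the core; it does not show how large the step on the core of compound 2 really is, as that step has only a lower bound, and two pairs cannot establish a rule for the series.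

The compounds shown leave open whether the gap between the two steps follows the methoxy group or the carboxymethyl group, both carried by compound 1 and compound 3 and absent from compound 2 and compound 4; no pair shown differs in only one of them. They also leave open how a plain benzyl group or a chlorobenzyl group would behave on either core.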